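The compounds below may be only part of what the source reports. "The series", "measured", "known", "first", "only" and "open" are said of these compounds alone.

Values in a functional assay on KYSE-450 cells (Homo sapiens) for inhibition, read by MTT assay, with a stated time of 48 h; on this read-out higher numbers stand for weaker inhibition and lower numbers for stronger inhibition:
- compound 1 `C#CC(=O)N(Cc1ccc(OC)c(O)c1)c1cc(OC)c(OC)c(OC)c1` gives 570 nM
- compound 2 `C/C=C/C=C/C(=O)N(Cc1ccc(OC)c(O)c1)c1cc(OC)c(OC)c(OC)c1` gives 180 nM

Compound 2 holds the lower number of the two. The next compound, compound 3 `COc1ccc(CN(C(=O)CCCl)c2cc(OC)c(OC)c(OC)c2)cc1O`, differs from it as follows: 2-chloroethyl in place of penta-1,3-dien-1-yl on a carbonyl carbon. Among the compounds with values here, the only measured step at this carbonyl carbon is a 3.2-fold lower number from compound 1 to compound 2 (0.50 log units; beyond the scatter), modest and beyond the scatter. A change of similar size towards a higher number is therefore expected, and the expected step is a 2.8-fold higher number from compound 2 to compound 3 (0.44 log units; beyond the scatter). The estimated value for compound 3 is 500 nM, with an expected range from 170 nM to 1500 nM.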

Compound 3, half-maximal inhibitory concentration: 110 nM
Beside the measured number, compound 3's estimate is 4.5-fold (0.66 log units) above it; measured number below the stated range.
By their numbers in this assay, from the lowest: compounds 3 and 2 (each within the scatter of the next); then compound 1.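

In this assay, 2-chloroethyl in place of penta-1,3-dien-1-yl on the carbonyl carbon gives a 1.6-fold lower number from compound 2 to compound 3 (0.21 log units; within the scatter), so the two double bonds of penta-1,3-dien-1-yl are not needed at this position to keep the number. Against ethynyl, the same group gives a 5.2-fold lower number from compound 1 to compound 3 (0.71 log units; beyond the scatter), which leaves ethynyl as the only one of the three groups standing apart. No measurement on hand gives a reason for these numbers.

The compounds shown leave open whether the chlorine itself counts, which a plain ethyl group would test, and how an aminoethyl group or a longer chloroalkyl chain would read on this carbonyl carbon.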